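Naphthalen-2-yl in Place of Phenyl on Compound 1

This account rests on a few compounds, and the source may have more. Where it says the series, first, only, none or still open, it means among the compounds named here.

Measured compounds:
compound 1, `CN1CCC(C(=O)N2Cc3c(NC(=O)c4ccccc4)n[nH]c3C2(C)C)CC1`: 160 nM
compound 2, `CC(=O)N1CCN(C(=O)N2Cc3c(NC(=O)c4ccc(F)cc4)n[nH]c3C2(C)C)CC1`: > 10000 nM
compound 3, `CCN1CCC(C(=O)N2Cc3c(NC(=O)CC(C)C)n[nH]c3C2(C)C)CC1`: 410 nM

Of the compounds shown here, three sharing one core have been tested in a functional assay on A2780 cells (Homo sapiens) for antiproliferative activity, read by fluorescence, with a stated time of 72 h; a lower number here means a stronger inhibitor, a higher number a weaker inhibitor. Compound 1 gives 160 nM, the lowest of the two numbers recorded. Compound 3 gives 410 nM, a higher number, and the gap between compound 1 and compound 3 lies beyond the scatter. For compound 2 the result is only a limit of the assay, (the limit of > 10000 nM in this assay, at which 1 of the 3 values shown sits), not a number.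

The next compound, compound 4, `CN1CCC(C(=O)N2Cc3c(NC(=O)c4ccc5ccccc5c4)n[nH]c3C2(C)C)CC1`, differs from compound 1 in a single place: naphthalen-2-yl in place of phenyl on a carbonyl carbon. Among the compounds with values here, no measured pair in this set differs by such a change, so there is no step to rest on; the expectation comes from compound 1 alone and from the modest size of the change on a carbonyl carbon whose other neighbour is an amide-type nitrogen. In this assay the step is expected to be small, in either direction, and not beyond the scatter. Compound 4 is estimated to give 200 nM, with a range from 60 nM to 700 nM. The step of a 1.3-fold higher number from compound 1 to compound 4 (0.10 log units; within the scatter) is therefore expected to stay within the scatter.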

Compound 4, half-maximal inhibitory concentration: 270 nM
For compound 4 the middle estimate is 1.4-fold (0.13 log units) below the measured one; measured number inside the range.
By their numbers in this assay, from the lowest: compounds 1, 4 and 3 (each within the scatter of the next, the first and the last beyond it). At a limit, above all of these: compound 2.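

In this assay, within the data shown here, the step of a 1.7-fold higher number from compound 1 to compound 4 (0.23 log units; within the scatter) gives the first reading of a single change in this set, and it shows that naphthalen-2-yl can take the place of phenyl on a carbonyl carbon whose other neighbour is an amide-type nitrogen without a shift beyond the scatter. The second six-membered aromatic ring of carbon only, which brings the entering group to more heavy atoms than phenyl, therefore leaves the antiproliferative reading within the scatter of compound 1 on the shared core, though this rests on one pair alone. No measurement shown here bears on what lies behind this step.

On these data alone, both groups compared are carbon-only aromatic rings, so it remains open how this position would respond to a pyridine ring, to a phenyl ring carrying an amine or a carboxylic acid, or to a longer chain. Also open, as far as these compounds go, are how naphthalen-1-yl would compare with naphthalen-2-yl, and whether the same replacement would give a similar step with the rest of compound 1 changed.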